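Bromo substitution on the shared indole-imidazole scaffold

The source may hold more compounds than are shown below. What is called first, only, known or untested is meant among the compounds shown, and "the series" means these compounds.

Measured compounds:
compound 1 `Cn1c(-c2cn(C)c3cc(Br)ccc23)cnc1-c1cn(C)c2ccccc12`: 800 nM
compound 2 `Cn1c(-c2cn(C)c3cc(Br)ccc23)cnc1-c1cn(C)c2cc(Br)ccc12`: 800 nM
compound 3 `Brc1ccc2c(-c3c[nH]c(-c4c[nH]c5ccccc45)n3)c[nH]c2c1`: 4500 nM

All three were run in a functional assay on P388 cells (Mus musculus) for cytotoxicity; a higher number here means a weaker inhibitor, a lower number a stronger inhibitor. Compound 1 and compound 2 differ in one place only, (bromo in place of hydrogen on an aromatic carbon), and the resulting step was no change at the digits printed from compound 1 to compound 2 (within the scatter); the two values lie within the scatter of each other, so no order between them can be read.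

Compound 3 carries the same kind of scaffold but its core differs from that of compound 1 in more than one place; the difference between the two cores is not broken down here. In this assay compound 3 gives 4500 nM, the highest number of the three, beyond the scatter relative to both compound 1 and compound 2.

Compound 4 `Brc1ccc2c(-c3c[nH]c(-c4c[nH]c5cc(Br)ccc45)n3)c[nH]c2c1` has not yet been measured. Within the data shown here, it relates to compound 3 by bromo in place of hydrogen on an aromatic carbon, which is the same change as the one made from compound 1 to compound 2: the leaving hydrogen, the entering bromo and the place described for it agree word for word. Because that earlier step was no change at the digits printed from compound 1 to compound 2 (within the scatter), the step from compound 3 to compound 4 is expected to be of similar size, estimated as no change at the digits printed from compound 3 to compound 4 (within the scatter). Compound 4 is therefore estimated at 4500 nM in this assay, with a range from 1800 nM to 11000 nM. This expectation rests on a single earlier pair and the difference between the two cores is not resolved, so the range is kept wide.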

Compound 4, half-maximal inhibitory concentration: 4500 nM
Compound 4: the middle estimate sits on the measured number at the digits printed; the measured number falls inside the stated range.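

In this assay, bromo in place of hydrogen on an aromatic carbon gives no change at the digits printed from compound 3 to compound 4 (within the scatter), so on this second core the change again leaves the read-out where it stood. Within the limits of these two pairs, the step carries from one core to the other, and no gap between the two steps can be read: the same change on two cores in this assay, no change at the digits printed (within the scatter) from compound 1 to compound 2 and no change at the digits printed (within the scatter) from compound 3 to compound 4, 1.0-fold (0.00 log units) apart, within the scatter of two such steps. This does not show that the change would behave in the same way on a third core or in any other assay, and two pairs with no measurable step offer no basis for a general rule, nor do they explain what the bromo does or does not do in the cells.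

Bromo is the only group entering at this place in the compounds shown, so it remains open whether an amine, a carboxylic acid or a longer chain such as n-butyl there would also leave the number unmoved. The difference between the core of compound 1 and the core of compound 3 also remains unresolved, since no pair shown separates it into single changes.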